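Isopropyl for Hydroxyethyl on a Weak Myosin-2 Inhibitor

The compounds below may be only part of what the source reports. "The series", "measured", "known", "first", "only" and "open" are said of these compounds alone.

Compound 1, `C/C(=N\CCO)c1c(O)c2ccccc2oc1=O`: 92000 nM
Compound 2, `CCC(C)/N=C(\C)c1c(O)c2ccccc2[nH]c1=O`: a limit of the assay, >= 100000 nM
Compound 3, `CCCC/N=C(\C)c1c(O)c2ccccc2[nH]c1=O`: a limit of the assay, >= 100000 nM

Going by the values given here, in an assay on isolated protein for inhibition of myosin-2 (Bos taurus), read by spectrophotometry, with a stated time of 24 min (a higher number here means a weaker inhibitor, a lower number a stronger inhibitor), compound 1 gives 92000 nM, the only actual number among the three measured compounds. The other two, compound 2 and compound 3, reach only the limit of the assay. Among the compounds with values here, the one measured step, a step that the two limits leave unreadable from compound 2 to compound 3, cannot be read because both of its values sit at the limit of >= 100000 nM in this assay, at which 2 of the 3 values shown sit. Compound 4, `C/C(=N\C(C)C)c1c(O)c2ccccc2oc1=O`, has not yet been measured. Its difference from compound 1 is isopropyl in place of 2-hydroxyethyl on a double-bonded nitrogen. Within the data shown here, no measured step touches this change, so nothing in the data argues for a shift beyond the usual scatter in either direction, while the two limits show how close the whole series sits to the edge of what this assay can report. Compound 4 is therefore expected to give 150000 nM, in a range from 40000 nM to 600000 nM, which means an expected step of a 1.6-fold higher number from compound 1 to compound 4 (0.21 log units; within the scatter), with a real chance that only a limit is returned.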

Compound 4, half-maximal inhibitory concentration: >= 100000 nM
Compound 4 gave a limit, no number; the forecaster's own chance of this, stated with the estimate: 60%; the middle value is on the limit's open side.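

In this assay compound 4 returns only a limit, >= 100000 nM, and not a number. This gives a first view of what happens on the double-bonded nitrogen of the core of compound 1: the step is an at least 1.0-fold higher number from compound 1 to compound 4 (0.03 log units; that floor lies within the scatter), so isopropyl in place of 2-hydroxyethyl brings no visible gain in strength, though any loss could be negligible or larger. The size of the effect of removing the hydroxyl stays unreadable because the values pile up at the edge of what can be reported: the limit of >= 100000 nM in this assay, at which 3 of the 4 values shown sit.

Still open, on these data alone, is whether any group on this nitrogen can bring the result to a readable number clearly stronger than that of compound 1. A longer chain ending in a hydroxyl, or a chain carrying an amine or a carboxylic acid, would test this on the same core.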